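Moving a halogen from the fourth to the third position

This account rests on a few compounds, and the source may have more. Where it says the series, first, only, none or still open, it means among the compounds named here.

Three compounds share a core carrying an aryl ring. Compound 1 `N=C(N)N/N=C/c1cn(-c2ccc([N+](=O)[O-])cc2[N+](=O)[O-])nc1-c1ccccc1Br` gives 78.1% in a functional assay on the whole organism (Ear) for inhibition, with Mus musculus as the target, with a stated time of 30 min, at a dose of 50 mg/kg by the intraperitoneal route; a lower number here means less inhibition, a higher number more inhibition at the dose given (going by the name of the read-out). Compound 2 `N=C(N)N/N=C/c1cn(-c2ccccc2)nc1-c1ccc(Br)cc1` gives 42.8% in this assay, and compound 3 `N=C(N)N/N=C/c1cn(-c2ccccc2)nc1-c1ccc(F)cc1` gives 61.4%. Compound 3 stands second of the three: beyond the scatter below compound 1 and beyond the scatter above compound 2. Going by the values given here, the one step between measured compounds that differ in one place is a number 18.6 percentage points higher from compound 2 to compound 3 (beyond the scatter). The change to compound 4 `N=C(N)N/N=C/c1cn(-c2ccccc2)nc1-c1cccc(Cl)c1` is 3-chlorophenyl in place of 4-fluorophenyl on an aromatic carbon. Chlorine lies between fluorine and bromine, so the one measured step suggests a modest fall; no measured pair tests the new position, so a step near the scatter is expected. The expected step is a number 9.4 percentage points lower from compound 3 to compound 4 (within the scatter). Compound 4 is estimated at 52%, within 35% to 70%.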

Compound 4, a percentage reported as inhibition, in the whole organism at one dose (the size of the read-out at that dose, not a potency): 93.6%
The estimate for compound 4 lay 41.6 percentage points below the measured number; measured number outside the range, above it.
By their numbers in this assay, from the lowest: compound 2; then compound 3; then compound 1; then compound 4.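

In this assay the 3-chlorophenyl group gives a large gain, with a number 32.2 percentage points higher from compound 3 to compound 4 (beyond the scatter) and a number 50.8 percentage points higher from compound 2 to compound 4 (beyond the scatter). Both steps are larger than the earlier change from bromo to fluoro, so this aryl group can shift the inhibition much further than that one step suggested. Nothing available explains the rise.

This swap changes both the halogen and its place on the ring, so these compounds cannot show which of the two matters. As far as these compounds go, whether an amine or a carboxylic acid could replace the chlorine and keep this inhibition also remains open.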